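Swapping the five-membered ring in an agonist series

The source may report more compounds than this note shows. Statements on the series, on what has been measured and on what is new or still open speak of the compounds shown alone.

Of the compounds shown here, two have been measured so far. In a functional assay with Alpha-1A adrenergic receptor (Homo sapiens) as the target, read by calcium flux (on this read-out higher numbers stand for larger maximal responses and lower numbers for smaller maximal responses), compound 1 `c1csc(-c2ccccc2OCC2=NCCN2)c1` gives 101%, and compound 2 `c1c[nH]c(-c2ccccc2OCC2=NCCN2)c1` gives 99%. The step of a number 2 percentage points lower from compound 1 to compound 2 (within the scatter) is within the scatter, so the two are indistinguishable on this read-out. Compound 3 `Cc1ccoc1-c1ccccc1OCC1=NCCN1` differs from compound 1 by 3-methylfuran-2-yl in place of thiophen-2-yl on an aromatic carbon. Going by the values given here, the one measured step, a comparable swap of the five-membered aromatic ring, bears on this change and was within the scatter. A step of a number 1 percentage points lower from compound 1 to compound 3 (within the scatter) is therefore expected, none beyond the scatter. Compound 3 is estimated to reach 100%, between 88% and 110%.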

Compound 3, largest response reached (reported as maximum), in percent of the reference or control that the assay uses: 99%
Compound 3: the middle estimate sits 1 percentage points above what was measured; low and high end bracket the measured number.
By their numbers in this assay, from the lowest: compounds 2, 3 and 1 (each within the scatter of the next).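

With 3-methylfuran-2-yl on this aromatic carbon, the step is a number 2 percentage points lower from compound 1 to compound 3 (within the scatter), and against the pyrrole it is no change at the digits printed from compound 2 to compound 3 (within the scatter). So a five-membered aromatic ring with oxygen as its hetero atom and a methyl group, one heavy atom larger than thiophen-2-yl, cannot be told apart from the two earlier rings in this assay. No supporting data explain this likeness.

Still open, going by these compounds, is whether an amine, a carboxylic acid or a longer chain at this place would give the same maximal response. These numbers also do not show how much of each compound is needed to reach that response.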